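Chloro for Cyano in an Oral Bioavailability Series

The compounds below may be only part of what the source reports. "The series", "measured", "known", "first", "only" and "open" are said of these compounds alone.

Measured compounds:
compound 1, `CNC(=O)c1ccc(-c2cnc3cnc(C(=O)N(C)c4ccc(C#N)cc4)cn23)cc1`: 51.9%
compound 2, `CN(C(=O)c1cn2c(-c3ccc(C(N)=O)cc3)cnc2cn1)c1ccc(F)cc1`: 51.6%
compound 3, `CN(C(=O)c1cn2c(-c3ccc(-c4nnc(N)s4)cc3)cnc2cn1)c1ccc(C#N)cc1`: 0.24%

In an ADME assay on the whole organism for pharmacokinetics, with Mus musculus as the target, at a dose of 20 mg/kg by the oral route (a lower number here means that a smaller share of the oral dose reaches the circulation, a higher number that a larger share of the oral dose reaches the circulation), compound 1 stands highest of the three numbers. Compound 2 lies within the scatter of compound 1, so no order between them can be claimed; compound 2 also differs from compound 1 in two places, so its values can only be read side by side. Compound 3 lies far below: a number 51.7 percentage points lower from compound 1 to compound 3 (beyond the scatter), a large step that follows a change on the other aryl ring and does not touch the position changed here.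

Compound 4, `CNC(=O)c1ccc(-c2cnc3cnc(C(=O)N(C)c4ccc(Cl)cc4)cn23)cc1`, has not been measured in this assay. It differs from compound 1 in one place: chloro in place of cyano on an aromatic carbon. Among the measured compounds shown here, no measured step bears directly on this exchange. Compound 2, which carries fluoro at the same place beside a second change, gives a value within the scatter of compound 1, which hints that this position tolerates a halogen.

For compound 4 the expectation is therefore no step beyond the scatter, a number 1.9 percentage points lower from compound 1 to compound 4 (within the scatter), with an estimated value of 50% and a range from 30% to 70%.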

Compound 4, oral bioavailability: 60%
Compound 4: middle estimate off by 10 percentage points, on the low side; the range from low to high includes it.
By their numbers in this assay, from the lowest: compound 3; then compounds 2, 1 and 4 (each within the scatter of the next).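

In this assay, chloro in place of cyano on an aromatic carbon gives a number 8.1 percentage points higher from compound 1 to compound 4 (within the scatter), so a single exchange at this place can now be read on its own. Compound 2 could only hint at this, since its fluoro came with a second change, whereas compound 4 keeps the rest of compound 1 intact and shows that the cyano group can give way to chloro with no step beyond the scatter. Nothing at hand speaks to what lies behind this result.

The compounds shown leave open whether a methoxy group, an amine or a carboxylic acid on the same carbon would also stay within the scatter of compound 1. They also leave open whether chloro would read the same alongside the 5-amino-1,3,4-thiadiazol-2-yl group of compound 3.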